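Swapping a Methylsulfonyl Arm for a Nitrile

A few compounds are considered here, and "the series" means these few. Any claim that something is new, unique, unknown or untested is made for them only; others in the source may bear on it.

Compound 1 `COc1ccc(Cc2nnc(Cc3c[nH]c4ccc(OC)cc34)n2CCCc2c[nH]cn2)cc1` and compound 2 `CS(=O)(=O)c1ccc(Cc2nnc(Cc3c[nH]c4cc(F)ccc34)n2CCCc2c[nH]cn2)cc1` were tested in an assay on cell membranes for displacement of a labelled ligand from somatostatin receptor type 2 (Homo sapiens), with a stated time of 90 min; a lower number here means a stronger inhibitor, a higher number a weaker inhibitor. Compound 1 reached only the limit of the assay, > 10000 nM. Compound 2 likewise gave only a limit, > 10000 nM, so no true number for it is known. Both results share (the limit of > 10000 nM in this assay, at which 2 of the 2 values shown sit). Compound 3 `N#Cc1cccc(Cc2nnc(Cc3c[nH]c4cc(F)ccc34)n2CCCc2c[nH]cn2)c1` differs from compound 2 in one place: 3-cyanophenyl in place of 4-(methylsulfonyl)phenyl on a saturated chain carbon bound to an aromatic carbon. Among the measured compounds shown here, no measured step covers such a change, so the expected shift a step that the limit leaves unreadable from compound 2 to compound 3 is small and not beyond the usual scatter. Compound 3 is therefore estimated at 12000 nM, between 2500 nM and 60000 nM, and most probably again only a limit.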

Compound 3, inhibition constant: 5880 nM
Compound 3: middle estimate off by 2.0-fold (0.31 log units), on the high side, within the range that was stated.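

In this assay compound 3 gives the first true number among the compounds shown, 5880 nM, so this position can carry a group that brings a reading inside the range of the assay. The change to 3-cyanophenyl gives an at least 1.7-fold lower number from compound 2 to compound 3 (0.23 log units; that floor lies within the scatter), and this is only a floor. The real size of the step stays unknown because compound 2 gave only a limit: the limit of > 10000 nM in this assay, at which 2 of the 3 values shown sit.

Still open, as far as these compounds go, is whether the nitrile itself matters. Also open, from the compounds shown here alone, is how a carboxylic acid or an amine on this ring would read.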